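From 2,3-difluorobenzyl to 3,4,5-trifluorobenzyl

The compounds below may be only part of what the source reports. "The series", "measured", "known", "first", "only" and "open" are said of these compounds alone.

Compound 1 `O=C(Nc1ccc(-c2cscn2)cc1)C1CCCN(Cc2ccccc2F)C1` gives 4000 nM
Compound 2 `O=C(Nc1ccc(-c2cscn2)cc1)C1CCCN(Cc2cccc(F)c2)C1` gives 2450 nM
Compound 3 `O=C(Nc1ccc(-c2cscn2)cc1)C1CCCN(Cc2cccc(F)c2F)C1` gives 1480 nM

In a functional assay on A-375 cells (Homo sapiens) for antiproliferative activity (a lower number here means a stronger inhibitor, a higher number a weaker inhibitor), there is a 2.7-fold lower number from compound 1 to compound 3 (0.43 log units; beyond the scatter) and there is a 1.7-fold lower number from compound 2 to compound 3 (0.22 log units; within the scatter) so compound 3 stands clear of compound 1 but level with compound 2. Compound 4 `O=C(Nc1ccc(-c2cscn2)cc1)C1CCCN(Cc2cc(F)c(F)c(F)c2)C1` differs from compound 3 by 3,4,5-trifluorophenyl in place of 2,3-difluorophenyl on a saturated chain carbon bound to an amine nitrogen in a ring and thus carries 3,4,5-trifluorophenyl in place of 2,3-difluorophenyl. The nearest evidence is those two steps of fluoro in place of hydrogen, along with a 1.6-fold lower number from compound 1 to compound 2 (0.21 log units; within the scatter) for a moved fluoro. Within the data shown here, all are small, and no compound here shows the new pattern. The step expected in this assay is a 1.0-fold higher number from compound 3 to compound 4 (0.01 log units; within the scatter) and so none beyond the scatter is expected. Compound 4 is estimated at 1500 nM with an expected range of 600 nM to 3500 nM in this read-out.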

Compound 4, half-maximal inhibitory concentration: 400 nM
Compound 4: the middle estimate sits 3.8-fold (0.57 log units) above what was measured; measured number below the stated range.
By their numbers in this assay, from the lowest: compound 4; then compounds 3, 2 and 1 (each within the scatter of the next, the first and the last beyond it).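

In this assay, the group on a saturated chain carbon bound to an amine nitrogen in a ring proves able to move the number further than the earlier fluoro changes showed. The 3,4,5-trifluorophenyl group gives a 3.7-fold lower number from compound 3 to compound 4 (0.57 log units; beyond the scatter) and a 6.1-fold lower number from compound 2 to compound 4 (0.79 log units; beyond the scatter) and a 10-fold lower number from compound 1 to compound 4 (1.00 log units; beyond the scatter) so compound 4 stands clear of all three earlier compounds. The fluoro pattern at this place therefore matters more than compounds 1 to 3 alone revealed. Going by these compounds, it remains open whether chloro or trifluoromethyl groups on this phenyl ring would give a similar number. Nothing available explains the gain.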